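Adding a methoxy group to compound 3

The source may hold more compounds than are shown below. What is called first, only, known or untested is meant among the compounds shown, and "the series" means these compounds.

Measured so far in an ADME assay on CCRF-CEM cells (Homo sapiens) for antiproliferative activity, with a stated time of 48 h; on this read-out higher numbers stand for weaker inhibition and lower numbers for stronger inhibition
compound 1 `C=C(Br)C(=O)Nc1ccc(C(=O)/C=C/c2cccc(OC)c2OC)cc1` gives 710 nM
compound 2 `COc1cccc(/C=C/C(=O)c2ccc(N)cc2)c1` gives 23000 nM
compound 3 `COc1ccccc1/C=C/C(=O)c1ccc(N)cc1` gives 6300 nM

Compound 3 stands in the middle of these three numbers. Its value (6300 nM) is lower than that of compound 2 and higher than that of compound 1, and both gaps lie beyond the usual scatter.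

Compound 4 `COc1cccc(/C=C/C(=O)c2ccc(N)cc2)c1OC` has not been measured yet. It differs from compound 3 by one change, methoxy in place of hydrogen on an aromatic carbon. The new group sits ortho to a methoxy group and meta to a large group.

Among the measured compounds shown here, no measured pair shows this change on its own, so the evidence is indirect. Compound 1 has its methoxy groups placed as in compound 4, but it carries a much larger group on its nitrogen, so its value says little here. Both compounds with a free amine give high numbers, compound 2 at 23000 nM and compound 3 at 6300 nM, and compound 4 is expected to stay in that region. The expected change in this assay is a 1.4-fold higher number from compound 3 to compound 4 (0.15 log units; within the scatter) (a small rise in the number, within the scatter). The estimated value for compound 4 is 9000 nM (expected range 3000 nM to 27000 nM).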

Compound 4, half-maximal inhibitory concentration: 7600 nM
Beside the measured number, compound 4's estimate is 1.2-fold (0.07 log units) above it; measured number inside the range.
By their numbers in this assay, from the lowest: compound 1; then compounds 3 and 4 (each within the scatter of the next); then compound 2.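

In this assay the new methoxy group, ortho to a methoxy group, brings a 1.2-fold higher number from compound 3 to compound 4 (0.08 log units; within the scatter) and so does not separate the two compounds, while the same kind of change made on compound 2 brings a 3.0-fold lower number from compound 2 to compound 4 (0.48 log units; beyond the scatter) and does separate them. Methoxy in place of hydrogen on this ring therefore has no single outcome across these three compounds, since what it does depends on which methoxy group is already there. Compound 1 and compound 4 carry the same methoxy groups, and an 11-fold higher number from compound 1 to compound 4 (1.03 log units; beyond the scatter) comes with hydrogen in place of (1-bromoethenyl)carbonyl on the nitrogen, a step larger than either methoxy step, so in this small set the group on the nitrogen weighs more than the second methoxy group.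

Still open, on these data alone, is whether another group at this position, such as an ethoxy group or an amine, would separate from compound 3, and whether the same holds once (1-bromoethenyl)carbonyl sits on the nitrogen. Nothing measured here gives a reason why the two methoxy steps differ in size.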